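Methyl Substitution on an Indole Core: Expected Cytotoxicity

The compounds below may be only part of what the source reports. "The series", "measured", "known", "first", "only" and "open" are said of these compounds alone.

Among the measured compounds shown here, compound 1 `O=C1CC(c2c(-c3ccc[nH]3)[nH]c3ccccc23)C(=O)N1` is the only member of this set with a number in a functional assay on PC-3 cells (Homo sapiens) for cytotoxicity, read by MTT assay, with a stated time of 72 h; on this read-out higher numbers stand for weaker inhibition and lower numbers for stronger inhibition: compound 1 gives 9000 nM. Compound 3 `O=C1NC(=O)c2c1c1[nH]ncc1c1[nH]c3ccccc3c21` reaches only a limit in this assay, namely > 100000 nM. Compound 2 `Cc1ccc2[nH]c3c4cn[nH]c4c4c(c3c2c1)C(=O)NC4=O` likewise shows only a limit in this assay, namely > 100000 nM. The difference between the cores of compound 1 and compound 3 is not broken down here. From compound 3 to compound 2 the change is methyl in place of hydrogen on an aromatic carbon, and the step was a step that the two limits leave unreadable from compound 3 to compound 2 because of the limit of > 100000 nM in this assay, at which 2 of the 3 values shown sit. Compound 4 `Cc1ccc2[nH]c(-c3ccc[nH]3)c(C3CC(=O)NC3=O)c2c1` carries the same kind of change relative to compound 1, (methyl in place of hydrogen on an aromatic carbon); around the place the ring is part of a fused or bridged system of two rings rather than five. Since the earlier step gives no readable size, the expected step in this assay is estimated as a 1.1-fold lower number from compound 1 to compound 4 (0.05 log units; within the scatter). Compound 4 is thus expected to give about 8000 nM, between 3000 nM and 25000 nM.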

Compound 4, half-maximal inhibitory concentration: 11000 nM
Beside the measured number, compound 4's estimate is 1.4-fold (0.14 log units) below it; the measured number falls inside the stated range.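

In this assay, methyl in place of hydrogen on an aromatic carbon on the core of compound 1 gives a 1.2-fold higher number from compound 1 to compound 4 (0.09 log units; within the scatter), so the two values cannot be told apart. On the core of compound 3 the same change cannot be read, because both compounds on that core sit at a limit of the assay: the limit of > 100000 nM in this assay, at which 2 of the 4 values shown sit. Among the compounds shown here, the series therefore offers only one readable step for this change, which shows that it is tolerated on the core of compound 1 but not whether the result carries over to the other core.

From the compounds shown here alone, it remains open whether an amine or a carboxylic acid at that place on the core of compound 1 would give a number beyond the scatter. Going by these compounds, the effect of a longer chain, such as ethyl, also remains open.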